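This account rests on a few compounds, and the source may have more. Where it says the series, first, only, none or still open, it means among the compounds named here.

Among the measured compounds shown here, compound 1 `O=C(O)CCc1ccccc1-c1cccc(-c2ccccc2OCc2ccccc2)c1` gives 55 nM in an assay on HEK293 cells for binding affinity to prostaglandin E2 receptor EP3 subtype (Homo sapiens) (a lower number here means a stronger inhibitor, a higher number a weaker inhibitor), and of the two compounds measured so far its number is the one that compound 3 will be compared against. Compound 2 `O=C(O)/C=C/c1ccccc1-c1cccc(-c2ccccc2OCc2ccccc2)c1` gives 84 nM in this assay, and the step of a 1.5-fold higher number from compound 1 to compound 2 (0.18 log units; within the scatter) sits within the scatter, so the two numbers are not distinguishable. Compound 3 `CC(Cc1ccccc1-c1cccc(-c2ccccc2OCc2ccccc2)c1)C(=O)O` differs from compound 1 by methyl in place of hydrogen on a saturated chain carbon bound to a carbonyl carbon and a saturated chain carbon. For the measured compounds named here, the one measured step also alters this chain and stayed within the scatter, so a similarly small step, with no clear direction, is expected, namely a 1.1-fold higher number from compound 1 to compound 3 (0.04 log units; within the scatter). Compound 3 is therefore estimated at 60 nM, between 25 nM and 150 nM.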

Compound 3, inhibition constant: 820 nM
For compound 3 the middle estimate is 14-fold (1.14 log units) below the measured one; the measured number lies above the stated range.
By their numbers in this assay, from the lowest: compounds 1 and 2 (each within the scatter of the next); then compound 3.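

The saturated chain carbon bound to the carbonyl carbon proves sensitive: in this assay one added methyl gives a 15-fold higher number from compound 1 to compound 3 (1.17 log units; beyond the scatter) while the earlier change in the same chain, from 2-carboxyethyl to 2-carboxyethenyl, stayed within the scatter. Set against the 2-carboxyethenyl chain, the 2-carboxypropyl chain gives a 9.8-fold higher number from compound 2 to compound 3 (0.99 log units; beyond the scatter) and so also fares worse. Nothing available explains this weaker binding.

As far as these compounds go, whether an ethyl or a fluorine on this same carbon would behave like the methyl remains open. So does the effect of a longer chain carrying the carboxylic acid.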